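The source may report more compounds than this note shows. Statements on the series, on what has been measured and on what is new or still open speak of the compounds shown alone.

Measured compounds:
compound 1 `O=c1cc(CNCc2ccccc2)oc2ccc(O)c(O)c12`: in an ADME assay on Huh-7 cells (Homo sapiens) for cytotoxicity (a higher number here means that more compound is tolerated, a lower number that less compound is tolerated), compound 1 reaches only the limit > 100000 nM.
compound 2 `O=c1cc(CNCc2ccccc2Cl)oc2ccc(O)c(O)c12`: compound 2 likewise reaches only the limit > 100000 nM in this assay.
compound 3 `O=c1cc(CNCc2cccc(O)c2)oc2ccc(O)c(O)c12`: compound 3 too reaches only the limit > 100000 nM in this assay.

Compound 1 thus stands at a limit, and the two other values are limits as well. Compound 4 `O=c1cc(CNCc2ccc(Cl)cc2)oc2ccc(O)c(O)c12` differs from compound 1 by chloro in place of hydrogen on an aromatic carbon. The nearest comparisons are the steps from compound 1 to compound 2, a step that the two limits leave unreadable from compound 1 to compound 2, and from compound 1 to compound 3, a step that the two limits leave unreadable from compound 1 to compound 3, which also add a single group on an aromatic carbon; their sizes cannot be read since (the limit of > 100000 nM in this assay, at which 3 of the 3 values shown sit). Among the compounds with values here, no measured step therefore sets a direction in this assay. Compound 4 is expected at 120000 nM, ranging from 60000 nM to 300000 nM. The expected step that the limit leaves unreadable from compound 1 to compound 4 is estimated as none beyond the scatter.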

Compound 4, half-maximal cytotoxic concentration: > 100000 nM
Compound 4 gave a limit, no number; the forecaster's own chance of this, stated with the estimate: 80%; the middle value does not contradict the limit.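

Compound 4 gives only a limit, so its steps from compound 1, compound 2 and compound 3 cannot be read: the limit of > 100000 nM in this assay, at which 4 of the 4 values shown sit. As far as these compounds go, how far these four compounds lie apart in this assay remains open, including whether chloro or hydroxy changes the tolerated concentration at all.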